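Hydroxy Removal on a Weakly Cytotoxic Biaryl Scaffold

The compounds below may be only part of what the source reports. "The series", "measured", "known", "first", "only" and "open" are said of these compounds alone.

Compound 1, `Oc1ccccc1-c1cncnc1`: 90000 nM
Compound 2, `COc1ccc(-c2ccccn2)c(OC)c1`: 234000 nM
Compound 3, `Oc1ccccc1-c1cccnc1`: 294000 nM

All three were tested in an ADME assay on HEK293 cells (Homo sapiens) for cytotoxicity, read by MTT assay, with a stated time of 2 days; a higher number here means a weaker inhibitor, a lower number a stronger inhibitor. Compound 1 gives 90000 nM, the lowest of the three numbers; compound 2 at 234000 nM and compound 3 at 294000 nM both lie beyond the scatter above it. For the measured compounds named here, no pair of measured compounds differs in a single place, so no measured step guides the next change.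

Compound 4, `c1ccc(-c2cncnc2)cc1`, differs from compound 1 in one place: hydrogen in place of hydroxy on an aromatic carbon. With nothing measured on this change, only a modest step is expected in this assay, toward a higher number if any, and possibly within the scatter. Compound 4 is therefore estimated at 150000 nM, between 50000 nM and 450000 nM. That estimate means a step of a 1.7-fold higher number from compound 1 to compound 4 (0.22 log units; within the scatter).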

Compound 4, half-maximal inhibitory concentration: > 400000 nM
Compound 4 was reported as a limit (the forecaster's own chance of this, stated with the estimate: 20%); at least 2.6-fold (0.42 log units) between middle value and limit.
By their numbers in this assay, from the lowest: compound 1; then compounds 2 and 3 (each within the scatter of the next). At a limit, above all of these: compound 4.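

In this assay, hydrogen in place of hydroxy on this aromatic carbon gives the first single-place comparison, with a step of an at least 4.4-fold higher number from compound 1 to compound 4 (0.64 log units; beyond the scatter), so the hydroxy on the core of compound 1 does matter to the read-out. The full size of this step cannot be given. Compound 4 gives > 400000 nM, which is a limit and not a number, and it stands alone at that limit: the limit of > 400000 nM in this assay, at which 1 of the 4 values shown sits.

The compounds shown leave open whether an amine or a carboxylic acid on this carbon would keep the number of compound 1. They also leave open whether the same change on compound 3 would give a similar step.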